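A few compounds are considered here, and "the series" means these few. Any claim that something is new, unique, unknown or untested is made for them only; others in the source may bear on it.

Measured so far in an ADME assay on microsomes from liver (Homo sapiens) for metabolic stability, read by LC-MS, with a stated time of 10 min, tested at 0.5 uM; a higher number here means that more of the compound is left, a lower number that less of the compound is left:
- compound 1 `c1ccc2c(c1)CN[C@@H](CN(CC1CCNCC1)[C@H]1CCCc3cccnc31)C2`: 86%
- compound 2 `c1cnc(CN(CCCN2CCNCC2)[C@H]2CCCc3cccnc32)nc1`: 100%
- compound 3 `c1cnc2c(c1)CCC[C@@H]2N(CCCN1CCNCC1)Cc1nc2ccccc2s1`: 50%

Compound 1 holds the second highest of the three numbers. Compound 2 is the nearest, higher by a margin beyond the scatter; compound 3 lies furthest, lower by a larger margin, also beyond the scatter. Within the data shown here, the one measured step that changes a single place is a number 50 percentage points lower from compound 2 to compound 3 (beyond the scatter); it replaces one aromatic group by another on a saturated chain carbon bound to an amine nitrogen and says nothing directly about the change now in view.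

Compound 4 `c1ccc2c(c1)CN[C@@H](CN(CCN1CCNCC1)[C@H]1CCCc3cccnc31)C2` differs from compound 1 in one place: (piperazin-1-yl)methyl in place of piperidin-4-yl on a saturated chain carbon bound to an amine nitrogen. The rest of the molecule, including the shared core, is unchanged. Among the measured compounds shown here, no measured pair exchanges piperidin-4-yl for (piperazin-1-yl)methyl, so the expectation rests on compound 1 alone, whose own value 86% already sits high in this assay. For the measured compounds named here, no step in this assay speaks to this kind of exchange. The expected step is a number 1 percentage points lower from compound 1 to compound 4 (within the scatter), that is, none beyond the scatter in either direction. Compound 4 is therefore expected to give about 85%, with a range from 68% to 100%.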

Compound 4, percent of the compound remaining: 96%
For compound 4 the middle estimate is 11 percentage points below the measured one, within the range that was stated.
By their numbers in this assay, from the lowest: compound 3; then compounds 1, 4 and 2 (each within the scatter of the next, the first and the last beyond it).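

In this assay, among these compounds, the pair of compound 1 and compound 4 gives the first reading of an exchange of the basic ring group itself: (piperazin-1-yl)methyl in place of piperidin-4-yl on a saturated chain carbon bound to an amine nitrogen yields a number 10 percentage points higher from compound 1 to compound 4 (within the scatter). The place therefore accepts this change of ring, and the extension of the chain to 2-(piperazin-1-yl)ethyl in the wider cut, with no step beyond the scatter, in contrast to the exchange of aromatic groups read as a number 50 percentage points lower from compound 2 to compound 3 (beyond the scatter). Nothing in the data available bears on why this exchange leaves the read-out within the scatter.

On these data alone, this rests on a single pair on one core, so it remains open whether the same exchange would read alike beside the 1,3-benzothiazol-2-yl group of compound 3, which gives 50% in this assay. Also open, as far as these compounds go, is how a morpholin-4-yl ring, an open-chain amine such as dimethylamino, or a carboxylic acid at this place would read in this assay.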